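The compounds below may be only part of what the source reports. "The series", "measured", "known", "first", "only" and "open" are said of these compounds alone.

Working notes on the series.

Compound 1 `O=C(CSc1nc(Nc2ccccc2)c2ccccc2n1)Nc1ccccc1Br` is the reference point. In a functional assay on MDA-MB-231 cells (Homo sapiens) for inhibition, read by MTT assay, with a stated time of 72 h (a lower number here means a stronger inhibitor, a higher number a weaker inhibitor), compound 1 gives 14100 nM. For the measured compounds named here, on the two numbers so far compound 1 sits at the upper end; the only other value, for compound 2 `C=CC(=O)Nc1cccc(NC(=O)CSc2nc(Nc3ccccc3)c3ccccc3n2)c1`, is separated from it by a 1.4-fold lower number from compound 1 to compound 2 (0.14 log units; within the scatter), and in this assay compound 2 gives 10200 nM. That single step exchanged the whole aryl group on the amide-type nitrogen and left the number essentially where it was.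

Compound 3 `O=C(CSc1nc(Nc2ccccc2)c2ccccc2n1)Nc1ccc(Br)cc1` is not yet measured. Compared with compound 1 the change is 4-bromophenyl in place of 2-bromophenyl on an amide-type nitrogen. Going by the values given here, the only measured step that bears on this position is the one from compound 1 to compound 2, which moved the number by a 1.4-fold lower number from compound 1 to compound 2 (0.14 log units; within the scatter). Since a far larger exchange at the same place stayed inside the scatter, moving the bromine from one position on the ring to another is expected to produce no step beyond the scatter in this assay, in either direction.

Compound 3 is therefore expected to give 14000 nM, with a range from 5000 nM to 40000 nM. The estimated step from compound 1 to compound 3, a 1.0-fold lower number from compound 1 to compound 3 (0.00 log units; within the scatter), is expected to lie within the scatter.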

Compound 3, half-maximal inhibitory concentration: 11500 nM
Beside the measured number, compound 3's estimate is 1.2-fold (0.09 log units) above it; the measured number falls inside the stated range.
By their numbers in this assay, from the lowest: compounds 2, 3 and 1 (each within the scatter of the next).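

Exchanging 2-bromophenyl for 4-bromophenyl on the amide-type nitrogen keeps the atoms the same and changes only how they are joined, and in this assay this gives a 1.2-fold lower number from compound 1 to compound 3 (0.09 log units; within the scatter), so this pair shows no effect of the bromine's placement on the ring beyond the scatter. The comparison of 4-bromophenyl with 3-((vinylcarbonyl)amino)phenyl at the same place gives a 1.1-fold higher number from compound 2 to compound 3 (0.05 log units; within the scatter), which means that all three aryl groups now measured on this nitrogen lie within the scatter of one another, and none of the three compounds goes against that. No evidence is available on what lies behind this flat result.

The compounds shown leave open whether a group of another kind on the amide-type nitrogen, such as an aryl ring carrying a carboxylic acid or an amine, or a longer alkyl chain in place of the aryl ring, would produce a step beyond the scatter. They also leave open whether changes elsewhere in the molecule, on the shared core or on its phenylamino group, would move the number at all.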